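This account rests on a few compounds, and the source may have more. Where it says the series, first, only, none or still open, it means among the compounds named here.

In an assay on cells for displacement of a labelled ligand from somatostatin receptor type 4 (Homo sapiens), with a stated time of 90 min (a lower number here means a stronger inhibitor, a higher number a weaker inhibitor), compound 1 `Clc1ccc(Cn2c(CCc3c[nH]cn3)nnc2Cc2c[nH]c3ccccc23)cc1Cl` gives > 10000 nM, which is a limit of the assay rather than a number. Compound 2 `Clc1ccc(Cn2c(Cc3c[nH]c4ccccc34)nnc2C2CCNCC2)cc1Cl` gives > 10000 nM, likewise a limit. Compound 3 `c1ccc(Cn2c(CCc3c[nH]c4ccccc34)nnc2C2CCNCC2)cc1` gives > 10000 nM, again a limit. The single step among these, a step that the two limits leave unreadable from compound 1 to compound 2, cannot be read, and the limit of > 10000 nM in this assay, at which 3 of the 3 values shown sit, describes where all three compounds stand. Within the data shown here, compound 4 `Clc1ccc(Cn2c(CCc3c[nH]cn3)nnc2CCc2c[nH]c3ccccc23)cc1Cl` differs from compound 1 by (1H-indol-3-yl)methyl in place of 1H-indol-3-yl on a saturated chain carbon bound to an aromatic carbon, a change that none of the measured steps covers. With every measured value sitting at a limit and no readable step available, compound 4 is expected to stay at the limit too, with a step that the limit leaves unreadable from compound 1 to compound 4 meaning no step beyond the scatter. The estimate for compound 4 in this assay is 15000 nM, within 3000 nM to 60000 nM.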

Compound 4, inhibition constant: 1430 nM
Compound 4: the middle estimate sits 10-fold (1.02 log units) above what was measured; measured number outside the range, below it.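

In this assay, among these compounds, the change on a saturated chain carbon bound to an aromatic carbon gives an at least 6.9-fold lower number from compound 1 to compound 4 (0.84 log units; beyond the scatter) and so provides the first readable step. Exchanging 1H-indol-3-yl for (1H-indol-3-yl)methyl is therefore enough to bring compound 4 off the limit, whereas the step between compound 1 and compound 2 cannot be read: the limit of > 10000 nM in this assay, at which 3 of the 4 values shown sit.

On these data alone, the full size of the step stays open, as the value of compound 1 is only a limit. Also open, as far as these compounds go, is whether a longer chain to the indole, or an amine in place of the 2-(1H-imidazol-4-yl)ethyl group, would lower the number further.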